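The source may report more compounds than this note shows. Statements on the series, on what has been measured and on what is new or still open speak of the compounds shown alone.

Measured compounds:
Compound 1, `CCCCCCNc1cncc(C(=O)NCc2ccccc2)n1`: 100000 nM in the cytotoxicity test.
Compound 2, `O=C(NCc1ccccc1)c1cncc(Cl)n1`: "not determined" (no result reported) in the cytotoxicity test.

Compound 1 `CCCCCCNc1cncc(C(=O)NCc2ccccc2)n1` was tested in an ADME assay on Vero cells (Chlorocebus sabaeus) for cytotoxicity, read by microscopy, with a stated time of 6 days (on this read-out lower numbers stand for higher toxicity in this test and higher numbers for lower toxicity in this test), and gave 100000 nM. Compound 2 `O=C(NCc1ccccc1)c1cncc(Cl)n1` shares the same core, but in this assay compound 2 gives "not determined" (no result reported), so it stands nowhere on the numbers shown; it is the starting point of the step only by structure. Compound 3 `CCCCCCCNc1cncc(C(=O)NCc2ccccc2)n1` is the unmeasured partner. It differs from compound 2 by heptylamino in place of chloro on an aromatic carbon. Within the data shown here, no step between measured compounds is recorded, so nothing can be said about how large a change this swap brings in this assay or in which direction. Compound 3 resembles compound 1 closely, differing only in the length of the alkylamino chain, so compound 3 is expected to land near compound 1, at about 100000 nM, with a plausible range from 30000 nM to 300000 nM.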

Compound 3, minimum cytotoxic concentration: > 100000 nM
Compound 3 ended at the assay's limit; the forecaster's own chance of this, stated with the estimate: 35%; the middle value sits exactly at the limit.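

In this assay the step reads a number no lower from compound 1 to compound 3 (the limit leaves the size open), so a methyl in place of hydrogen on the saturated chain brought no sign of greater toxicity at this position. In this assay compound 3 gives > 100000 nM, which is a limit of the assay and not a number. The size of the step cannot be read because of this limit: the limit of > 100000 nM in this assay, at which 1 of the 3 values shown sits.

Compound 2 gives "not determined" (no result reported), so the compounds shown leave open how chloro compares with the alkylamino chains at this position. Also open, on these data alone, is whether a shorter chain, a longer chain or a cyclic amine on this aromatic carbon would give a measurable reading in this assay.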